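The source may hold more compounds than are shown below. What is called first, only, known or untested is meant among the compounds shown, and "the series" means these compounds.

Measured compounds in a functional assay, tested at 2.5 mM; a lower number here means less inhibition, a higher number more inhibition at the concentration tested (going by the name of the read-out):
compound 1 `CC(C)C[C@@H]1NC(=O)[C@H](CCC(N)=O)NC1=O`: 0%
compound 2 `CSCC[C@@H]1NC(=O)[C@H](CC(C)C)NC1=O`: 0%
compound 3 `CC(C)C[C@@H]1NC(=O)[C@H](CS)NC1=O`: 83.3%

Compound 3 stands highest of the three numbers in this assay; compounds 1 and 2 sit together far below it. The steps of a number 83.3 percentage points higher from compound 1 to compound 3 (beyond the scatter) and a number 83.3 percentage points higher from compound 2 to compound 3 (beyond the scatter) are both large, and no change at the digits printed from compound 1 to compound 2 (within the scatter) is flat. Compound 4 `CC(C)C[C@@H]1NC(=O)[C@H](CC(=O)O)NC1=O` differs from compound 3 by carboxy in place of sulfanyl on a saturated chain carbon bound to a saturated ring carbon. Among the compounds with values here, no measured step exchanges sulfanyl for carboxy. Within the data shown here, what the series shows is that the only compound with inhibition is compound 3, and the two compounds carrying other groups on this chain carbon, compounds 1 and 2, give none. On that basis a large fall is expected for compound 4, a number 73.3 percentage points lower from compound 3 to compound 4 (beyond the scatter). Compound 4 is estimated at 10%, in the range 0% to 40%.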

Compound 4, a percentage reported as inhibition, at one concentration (the size of the read-out at that concentration, not a potency): 0%
For compound 4 the middle estimate is 10 percentage points above the measured one; low and high end bracket the measured number.
By their numbers in this assay, from the lowest: compounds 1, 2 and 4 (each within the scatter of the next); then compound 3.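

In this assay, carboxy in place of sulfanyl on this chain carbon gives a number 83.3 percentage points lower from compound 3 to compound 4 (beyond the scatter) and does not retain inhibition. Carboxy also matches the other two groups at this position, with no change at the digits printed from compound 2 to compound 4 (within the scatter) and no change at the digits printed from compound 1 to compound 4 (within the scatter), so sulfanyl remains the only group shown here with inhibition. No evidence on the reason for this is available.

From the compounds shown here alone, it remains open whether inhibition needs sulfanyl specifically or would also appear with a hydroxy group on this chain carbon. A longer chain ending in sulfanyl is also untested within the compounds shown.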